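Replacing the 2-fluoro-4-methylphenyl group of compound 3

This account rests on a few compounds, and the source may have more. Where it says the series, first, only, none or still open, it means among the compounds named here.

In a functional assay on A549 cells (Homo sapiens) for antiproliferative activity, read by MTT assay, with a stated time of 72 h (on this read-out higher numbers stand for weaker inhibition and lower numbers for stronger inhibition), compound 1 `COc1ccccc1-c1ccc2ncn(-c3cc(OC)c(OC)c(OC)c3)c2c1` gives 4320 nM and compound 2 `COc1cc(-n2cnc3ccc(-c4ccc(C(C)=O)cc4)cc32)cc(OC)c1OC` gives 2510 nM, the step being a 1.7-fold lower number from compound 1 to compound 2 (0.24 log units; within the scatter). Compound 3 `COc1cc(-n2cnc3ccc(-c4ccc(C)cc4F)cc32)cc(OC)c1OC` gives only a limit of the assay, > 10000 nM. Compound 4 `COc1ccc(-c2ccc3ncn(-c4cc(OC)c(OC)c(OC)c4)c3c2)cc1F` carries 3-fluoro-4-methoxyphenyl in place of 2-fluoro-4-methylphenyl on an aromatic carbon. Among the compounds with values here, two measured steps bear on this change, an at least 2.3-fold higher number from compound 1 to compound 3 (0.36 log units; beyond the scatter) and an at least 3.9-fold higher number from compound 2 to compound 3 (0.60 log units; beyond the scatter), and both are open-ended as they enter the same group that now leaves. A return towards the range of the other two measured compounds is therefore expected. The expected step is an at least 2.2-fold lower number from compound 3 to compound 4 (0.34 log units; beyond the scatter), towards stronger inhibition. Compound 4 is estimated at 4500 nM, with an expected range of 1800 nM to 10000 nM.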

Compound 4, half-maximal inhibitory concentration: 1430 nM
For compound 4 the middle estimate is 3.1-fold (0.50 log units) above the measured one; the measured number lies below the stated range.
By their numbers in this assay, from the lowest: compounds 4, 2 and 1 (each within the scatter of the next, the first and the last beyond it). At a limit, above all of these: compound 3.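

Compound 3 stands at a limit of the assay, not at a number: the limit of > 10000 nM in this assay, at which 1 of the 4 values shown sits. With 3-fluoro-4-methoxyphenyl on this aromatic carbon, this assay shows an at least 6.9-fold lower number from compound 3 to compound 4 (0.84 log units; beyond the scatter), so the loss seen with 2-fluoro-4-methylphenyl does not extend to every fluorinated phenyl group here. Within the data shown here, the series also gains a 3.0-fold lower number from compound 1 to compound 4 (0.48 log units; beyond the scatter), the only step between two exact values that lies beyond the scatter, while a 1.8-fold lower number from compound 2 to compound 4 (0.24 log units; within the scatter) leaves compound 2 and compound 4 unseparated.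

Which part of the 3-fluoro-4-methoxyphenyl group matters, the fluorine or the methoxy, stays open. So does the effect of an amine or a carboxylic acid on this phenyl ring.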